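Working notes: cytotoxicity series with three limits, one open compound

This account rests on a few compounds, and the source may have more. Where it says the series, first, only, none or still open, it means among the compounds named here.

Measured so far:
compound 1 `Cn1c(-c2ccccc2)cnc1NC(=O)c1ccc(Cl)cc1` — > 100000 nM
compound 2 `COc1ccc(-c2cnc(NC(=O)c3cccc(Br)c3)n2C)cc1` — > 100000 nM
compound 3 `COc1ccc(-c2cnc(NC(=O)c3ccccc3OC)n2C)cc1` — > 100000 nM

In a toxicity assay on THP-1 cells (Homo sapiens) for inhibition (on this read-out higher numbers stand for lower toxicity in this test and lower numbers for higher toxicity in this test), compound 1 gives > 100000 nM, which is a limit of the assay and not a number. Compound 2 likewise stops at a limit. Compound 3 also stops at a limit. Hence (the limit of > 100000 nM in this assay, at which 3 of the 3 values shown sit), and compound 1 cannot be placed relative to the others. Among the measured compounds shown here, the single one-place step, a step that the two limits leave unreadable from compound 2 to compound 3, is unreadable for the same reason.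

Compound 4 `Cn1c(-c2ccccc2)cnc1NC(=O)c1ncc[nH]1` differs from compound 1 by 1H-imidazol-2-yl in place of 4-chlorophenyl on a carbonyl carbon. For the measured compounds named here, no measured step touches this exchange at the carbonyl carbon, so nothing points to a change beyond the scatter. The step of a number no higher from compound 1 to compound 4 (the limit leaves the size open) is therefore expected to be none, with compound 4 most likely again at the limit. The estimate for compound 4 is 100000 nM, ranging from 30000 nM to 300000 nM.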

Compound 4, half-maximal cytotoxic concentration: > 100000 nM
Compound 4: only a limit was reported; the forecaster's own chance of this, stated with the estimate: 80%; the middle value sits exactly at the limit.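

No step can be read from compound 1 to compound 4, because both stop at a limit of the assay and not at a number: the limit of > 100000 nM in this assay, at which 4 of the 4 values shown sit.

The compounds shown leave open whether this assay gives a readable value for any exchange on the carbonyl carbon.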